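The source may hold more compounds than are shown below. What is called first, only, known or untested is meant among the compounds shown, and "the series" means these compounds.

In an assay on CHO-K1 cells for displacement of a labelled ligand from prostaglandin E2 receptor EP1 subtype (Homo sapiens) (a lower number here means a stronger inhibitor, a higher number a weaker inhibitor), compound 3 `Cc1cc(NC(=O)C2CCCO2)nn1Cc1cc(Cl)ccc1OCc1ccccc1` gives 39.8 nM, the lowest of the three numbers seen so far; compound 1 `Cc1cc(C(=O)NCc2cccnc2)nn1Cc1cc(Cl)ccc1OCc1ccccc1` gives 50.1 nM, a gap that lies within the scatter, while compound 2 `CC(=O)Nc1cc(C)n(Cc2cc(Cl)ccc2OCc2ccccc2)n1` gives 316 nM, a gap beyond it. Compound 4 `Cc1cc(NC(=O)O[C@H]2CCOC2)nn1Cc1cc(Cl)ccc1OCc1ccccc1` differs from compound 3 at the carbonyl carbon whose other neighbour is the amide-type nitrogen: (oxolan-3-yl)oxy in place of oxolan-2-yl on a carbonyl carbon. Within the data shown here, two measured steps touch this part of the shared core. Among the measured compounds shown here, replacing the whole side group gave a 1.3-fold lower number from compound 1 to compound 3 (0.10 log units; within the scatter), and the exchange on the carbonyl carbon gave a 7.9-fold lower number from compound 2 to compound 3 (0.90 log units; beyond the scatter), so the substituent on this carbonyl carbon can shift the number, but an oxy-linked oxolane has no measured precedent here. A small step in either direction is therefore expected, estimated as a 1.5-fold higher number from compound 3 to compound 4 (0.18 log units; within the scatter). For compound 4 in this assay the expected value is 60 nM, estimated to fall between 20 nM and 200 nM.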

Compound 4, half-maximal inhibitory concentration: 79.4 nM
Compound 4: the middle estimate sits 1.3-fold (0.12 log units) below what was measured; the range from low to high includes it.
By their numbers in this assay, from the lowest: compounds 3, 1 and 4 (each within the scatter of the next); then compound 2.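

In this assay, the (oxolan-3-yl)oxy group on the carbonyl carbon fits the series: a 2.0-fold higher number from compound 3 to compound 4 (0.30 log units; within the scatter) and a 1.6-fold higher number from compound 1 to compound 4 (0.20 log units; within the scatter) both stay within the scatter, while a 4.0-fold lower number from compound 2 to compound 4 (0.60 log units; beyond the scatter) stays beyond it. Among these compounds, an oxolane ring on this carbonyl carbon, whether attached directly or through oxygen, therefore gives a lower number than methyl does. No measurement offered here explains this separation from methyl.

The compounds shown leave open what the opposite configuration at the defined stereocentre of compound 4 would give. They also leave open whether the ring oxygen counts, which a cyclopentyloxy group or an open chain such as 2-methoxyethoxy on the same carbonyl carbon could test.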